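The compounds below may be only part of what the source reports. "The series", "measured", "known", "first", "only" and "open" are said of these compounds alone.

Measured compounds:
- compound 1 `Cn1ncc2c(=O)n(-c3ccccc3)c(COc3cccc(F)c3)nc21`: 8200 nM
- compound 2 `COc1cccc(C(C)Sc2nc3c(cnn3C)c(=O)n2-c2ccccc2)c1`: 451 nM

In an assay on isolated protein for inhibition of aldehyde dehydrogenase 1A1 (Homo sapiens) (on this read-out higher numbers stand for weaker inhibition and lower numbers for stronger inhibition), compound 2 gives 451 nM, the lowest of the two numbers measured. Going by the values given here, compound 1, the only other measured compound, gives 8200 nM in this assay, a higher number that lies beyond the usual scatter, so compound 2 is the stronger inhibitor of the two. Among the compounds with values here, the two compounds differ in several places at once, so no single-change step is available from them.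

Compound 3 `CC(Sc1nc2c(cnn2C)c(=O)n1-c1ccccc1)c1cncnc1` differs from compound 2 in one place: pyrimidin-5-yl in place of 3-methoxyphenyl on a saturated chain carbon bound to a saturated chain carbon and a sulfur. Within the data shown here, no measured pair shows this kind of exchange, so there is nothing to set its size from directly. The change is expected to raise the number, meaning somewhat weaker inhibition, by a step of a 3.3-fold higher number from compound 2 to compound 3 (0.52 log units; beyond the scatter) from the value of compound 2. Compound 3 is therefore estimated at 1500 nM in this assay, with a range from 400 nM to 6000 nM.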

Compound 3, half-maximal inhibitory concentration: 94 nM
Compound 3: middle estimate off by 16-fold (1.20 log units), on the high side; the whole stated range lies above it.
By their numbers in this assay, from the lowest: compound 3; then compound 2; then compound 1.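

Measured in this assay the exchange of 3-methoxyphenyl for pyrimidin-5-yl on a saturated chain carbon bound to a saturated chain carbon and a sulfur gives a 4.8-fold lower number from compound 2 to compound 3 (0.68 log units; beyond the scatter) and so stronger inhibition. Going by these compounds alone, this is the first comparison in which only one place changes, and it shows that a carbon-only ring carrying a methoxy group is not required here: a six-membered aromatic ring with 2 hetero atoms gives the lower number. Nothing measured here explains this gain.

The compounds shown leave open whether the gain comes from the two ring nitrogens or from losing the methoxy group, a question that an unsubstituted phenyl at this place would help to settle. Going by these compounds, how a pyridin-3-yl ring or a non-aromatic group such as morpholine would fare at this place also remains open.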